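The source may report more compounds than this note shows. Statements on the series, on what has been measured and on what is new or still open speak of the compounds shown alone.

Values in an ADME assay on HepG2 cells (Homo sapiens) for cytotoxicity, read by luminescence, with a stated time of 72 h (a lower number here means that less compound is needed, a higher number that more compound is needed for the effect), for the measured compounds

Compound 1 `CCOC(=O)c1c(-c2cccc(OC(C)C)c2)[nH]c2cc(OC)ccc2c1=O` gives > 21500 nM
Compound 2 `CCOC(=O)c1c(-c2cccc(F)c2)[nH]c2cc(OC)ccc2c1=O` gives > 21500 nM
Compound 3 `CCOC(=O)c1c(-c2cccc(Cl)c2)[nH]c2cc(OC)ccc2c1=O` gives > 21500 nM

All three values are limits of the assay, not numbers. Compound 3 sits at the limit > 21500 nM and so offers no exact number to start from. Compound 4 `CCOC(=O)c1c(-c2cccc(N(C)C)c2)[nH]c2cc(OC)ccc2c1=O` has dimethylamino in place of chloro on an aromatic carbon, meta to a large group, and the change counts as dimethylamino in place of chloro on an aromatic carbon in full. The measured steps are a step that the two limits leave unreadable from compound 1 to compound 2 and a step that the two limits leave unreadable from compound 1 to compound 3 and a step that the two limits leave unreadable from compound 2 to compound 3 and none has a readable size. What remains is the limit of > 21500 nM in this assay, at which 3 of the 3 values shown sit, and this points to no step beyond the scatter in this assay in either direction. The expected step is a step that the limit leaves unreadable from compound 3 to compound 4 on this estimate. For compound 4 the estimated value is 25000 nM with 10000 nM to 40000 nM as the expected range.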

Compound 4, half-maximal effective concentration: > 21500 nM
Compound 4: no number, only a limit (the forecaster's own chance of this, stated with the estimate: 70%); the middle value is on the limit's open side.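

Compound 4, like compound 1, compound 2 and compound 3, gives a limit and not a number, and no step among these compounds can be read: the limit of > 21500 nM in this assay, at which 4 of the 4 values shown sit.

The compounds shown leave open whether these four groups differ at all in the concentration needed for the half-maximal effect.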